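The source may hold more compounds than are shown below. What is called first, only, known or untested is meant among the compounds shown, and "the series" means these compounds.

Compound 1 `CC1(COc2ccc(-c3ccc(F)cc3)cc2)Cn2cc([N+](=O)[O-])nc2O1`: in an ADME assay on MRC5 cells (Homo sapiens) for cytotoxicity, read by fluorescence, with a stated time of 72 h (a lower number here means a stronger inhibitor, a higher number a weaker inhibitor), compound 1 gives > 64000 nM, which is a limit of the assay and not a number.
Compound 2 `CC1(COc2ccc(C(F)(F)F)cc2)Cn2cc([N+](=O)[O-])nc2O1`: in this assay compound 2 gives > 64000 nM, again a limit of the assay.
Compound 3 `CC1(COc2ccc(C(F)(F)F)cn2)Cn2cc([N+](=O)[O-])nc2O1`: in this assay compound 3 gives > 64000 nM, also a limit of the assay.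

Compounds 1 and 2 share a core and differ in one place: 4-fluorophenyl in place of trifluoromethyl on an aromatic carbon. The step this change made is a step that the two limits leave unreadable from compound 2 to compound 1, and it cannot be read because of the limit of > 64000 nM in this assay, at which 3 of the 3 values shown sit. Compound 3 carries a different core; the difference between the two cores is not broken down here, and what is known of compound 3 in this assay is only a limit.

Compound 4 `CC1(COc2ccc(-c3ccc(F)cc3)cn2)Cn2cc([N+](=O)[O-])nc2O1` has not been measured in this assay. It differs from compound 3 by 4-fluorophenyl in place of trifluoromethyl on an aromatic carbon. This is the same kind of change as that from compound 2 to compound 1, not the same: in compound 1 the 4-fluorophenyl sits on an aromatic carbon of a six-membered aromatic ring of carbon only, para to a large group, whereas in compound 4 it sits on an aromatic carbon of a six-membered aromatic ring with 1 nitrogen, two atoms from the ring nitrogen, para to a large group.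

Going by the values given here, since every value so far sits at a limit, the step from compound 3 to compound 4 is expected to be a step that the limit leaves unreadable from compound 3 to compound 4, with compound 4 expected to give 80000 nM, between 30000 nM and 250000 nM, most likely again reported only as a limit.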

Compound 4, half-maximal inhibitory concentration in the MRC5 assay: > 64000 nM
Compound 4: a limit, no number; the forecaster's own chance of this, stated with the estimate: 85%; the middle value does not contradict the limit.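

In the MRC5 assay compound 3 gives > 64000 nM, which is a limit of the assay and not a number. In the MRC5 assay compound 4 gives > 64000 nM, which is also a limit of the assay and not a number. The change from trifluoromethyl to 4-fluorophenyl therefore gives no readable step between these two compounds in the MRC5 assay: the limit of > 64000 nM in the MRC5 assay, at which 4 of the 4 values shown sit. The compounds shown leave open whether any of the four differs from another in the MRC5 assay, and how large any such difference would be. In a physicochemical assay for solubility, read by HPLC, measured as kinetic solubility, at 20 degrees C, at pH 1 (a lower number here means a less soluble compound, a higher number a more soluble compound), compound 3 gives 11 ug/mL and compound 4 gives 2.7 ug/mL. With 4-fluorophenyl in place of trifluoromethyl, the physicochemical assay shows a 4.1-fold lower number from compound 3 to compound 4 (0.61 log units; beyond the scatter).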